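Chain length on the thiol-ketone side chain of compound 2

The source may report more compounds than this note shows. Statements on the series, on what has been measured and on what is new or still open speak of the compounds shown alone.

Compound 2 `CNC(=O)[C@@H](NC(=O)[C@@H](CC(=O)CS)CC(C)C)C(C)(C)C` is the reference point of this pair. In an assay on isolated protein for inhibition of matrix metalloproteinase-9 (Homo sapiens) (on this read-out higher numbers stand for weaker inhibition and lower numbers for stronger inhibition), compound 2 gives 8 nM, the lowest of the two numbers recorded so far. Among the measured compounds shown here, the only other measured compound, compound 1 `CCCCCCC[C@H](C[C@H](O)CS)C(=O)N[C@@H](CC(C)C)C(=O)NC(=O)C(CC(C)C)NCC`, gives 24 nM in this assay, a higher number that lies beyond the scatter of repeated measurements; compound 1 differs from compound 2 in several places at once, so no single-change step can be read from this pair.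

Compound 3 `CCCCCCC[C@H](CC(=O)CS)C(=O)N[C@H](C(=O)NC)C(C)(C)C` has not yet been measured. It differs from compound 2 in one place: hexyl in place of isopropyl on a saturated chain carbon, two bonds along the chain from a carbonyl carbon. For the measured compounds named here, no measured pair isolates this change. Compound 1, which carries the heptyl side chain, gives the weaker number of 24 nM. Compound 1 also differs from compound 2 in other places, so this pair does not isolate the chain. The expectation for compound 3 is therefore a small step toward weaker inhibition, at most modestly beyond the scatter, expressed as a 1.8-fold higher number from compound 2 to compound 3 (0.24 log units; within the scatter). Compound 3 is estimated at 14 nM in this assay, with a range from 4 nM to 45 nM.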

Compound 3, half-maximal inhibitory concentration: 0.14 nM
The estimate for compound 3 lay 100-fold (2.00 log units) above the measured number; measured number below the stated range.
By their numbers in this assay, from the lowest: compound 3; then compound 2; then compound 1.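

In this assay, the saturated chain carbon two bonds along the chain from a carbonyl carbon proves highly sensitive to the group it carries: hexyl in place of isopropyl gives a 57-fold lower number from compound 2 to compound 3 (1.76 log units; beyond the scatter). Among the compounds shown here, this is the first single-change step, and it shows that this position can drive a large gain in inhibition, not merely tolerate a change. Only carbon differs between the two groups, with no ring, hydrogen-bond donor, hydrogen-bond acceptor or net charge entering or leaving, and nothing in the data explains the size of the step.

With only isopropyl and hexyl compared at this position, the data do not show whether the number keeps falling with a longer chain such as octyl or decyl, or whether hexyl is near the best length. They also leave open whether this position accepts a chain ending in a phenyl ring, an amine or a carboxylic acid, and whether the large step from hexyl would carry over to such groups.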